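Swapping the chlorophenyl of compound 2 for a fused bicyclic group

The source may hold more compounds than are shown below. What is called first, only, known or untested is meant among the compounds shown, and "the series" means these compounds.

Measured so far:
compound 1 `C=C1CC[C@@H]2[C@](C)(CNCc3ccc(O)c(O)c3)[C@H](O)CC[C@@]2(C)[C@@H]1/C=C/C1=CCOC1=O` — 9440 nM
compound 2 `C=C1CC[C@@H]2[C@](C)(CNCc3ccc(Cl)cc3)[C@H](O)CC[C@@]2(C)[C@@H]1/C=C/C1=CCOC1=O` — 420 nM

Both compounds were tested in a functional assay on BMMC cells (Mus musculus, strain C57BL/6) for inhibition, with stated times of 5 days and 48 h; a lower number here means a stronger inhibitor, a higher number a weaker inhibitor. For the measured compounds named here, compound 2 stands as the lower of the two numbers; its only neighbour is compound 1, and the step of a 22-fold lower number from compound 1 to compound 2 (1.35 log units; beyond the scatter) shows that the exchange of the 3,4-dihydroxyphenyl for a 4-chlorophenyl made a large difference. Compound 3 `C=C1CC[C@@H]2[C@](C)(CNCc3ccc4c(c3)CC=N4)[C@H](O)CC[C@@]2(C)[C@@H]1/C=C/C1=CCOC1=O` has not been measured in this assay. It differs from compound 2 in one place: a group of 9 heavy atoms (8 carbon, 1 nitrogen; one five-membered non-aromatic ring with 1 hetero atom, one six-membered aromatic ring of carbon only) in place of a group of 7 heavy atoms (6 carbon, 1 chlorine; one six-membered aromatic ring of carbon only), on a saturated chain carbon bound to an amine nitrogen. Going by the values given here, the only measured step bears on the same site, but the entering group here is neither the 3,4-dihydroxyphenyl nor the 4-chlorophenyl, so that step tells only that this position responds strongly. A modest change is therefore expected, a 1.9-fold higher number from compound 2 to compound 3 (0.28 log units; within the scatter), with compound 3 estimated at 800 nM in this assay, within a range of 250 nM to 2500 nM.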

Compound 3, half-maximal inhibitory concentration: 550 nM
Compound 3: middle estimate off by 1.5-fold (0.16 log units), on the high side; measured number inside the range.
By their numbers in this assay, from the lowest: compounds 2 and 3 (each within the scatter of the next); then compound 1.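

In this assay the exchange at this position gives a 1.3-fold higher number from compound 2 to compound 3 (0.12 log units; within the scatter), so a fused bicyclic group with a hydrogen-bond acceptor and a single 4-chlorophenyl ring cannot be told apart on a saturated chain carbon bound to an amine nitrogen. The comparison with the 3,4-dihydroxyphenyl gives a 17-fold lower number from compound 1 to compound 3 (1.23 log units; beyond the scatter), which shows that the large difference seen earlier does not depend on the 4-chlorophenyl alone, as two quite different groups now stand apart from compound 1. No available evidence explains these numbers.

It remains open whether both hydroxyl groups of the 3,4-dihydroxyphenyl are needed for the weaker number of compound 1, as a 4-hydroxyphenyl or an unsubstituted phenyl is not among the compounds shown. Going by these compounds, how a carboxylic acid on the ring, or a longer chain before it, would read here also remains open.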